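A few compounds are considered here, and "the series" means these few. Any claim that something is new, unique, unknown or untested is made for them only; others in the source may bear on it.

Measured so far:
compound 1 `CC(C)N(Cc1cccc(OCCCCCC(=O)O)c1)C(=O)c1ccc(-c2cccc(F)c2)cc1` gives in an ADME assay on Raji cells (Homo sapiens) for cytotoxicity, read by CellTiter-Glo and resazurin assay, with a stated time of 72 h (a lower number here means that less compound is needed, a higher number that more compound is needed for the effect), a value that is only a limit of the assay, > 26000 nM.
compound 2 `CCOC(=O)CCCCCOc1cccc(CN(C(=O)c2ccc(-c3cnc(OC)nc3OC)cc2)C(C)C)c1` gives in this assay likewise only a limit, > 26000 nM.

Compound 2 therefore stands at the limit of this assay, where both values shown sit (the limit of > 26000 nM in this assay, at which 2 of the 2 values shown sit), so no number for it is known. Compound 3 `CCOC(=O)CCCCCOc1cccc(CN(C(=O)c2ccc(-c3cccc(O)c3)cc2)C(C)C)c1` differs from compound 2 in one place (3-hydroxyphenyl in place of 2,4-dimethoxypyrimidin-5-yl on an aromatic carbon). For the measured compounds named here, with no measured step between the two compounds to draw on, the expected step of a number no higher from compound 2 to compound 3 (the limit leaves the size open) is none beyond the scatter. Compound 3 is estimated at 26000 nM, within 8000 nM to 80000 nM, most likely again reported as a limit.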

Compound 3, half-maximal effective concentration: > 26000 nM
Compound 3 gave a limit, no number; the forecaster's own chance of this, stated with the estimate: 75%; the middle value sits exactly at the limit.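

No step from compound 2 to compound 3 can be read, because each is reported only as a limit, not a number: the limit of > 26000 nM in this assay, at which 3 of the 3 values shown sit.

The compounds shown leave open how much of any of them is needed for the effect in this assay, and whether 3-hydroxyphenyl in place of 2,4-dimethoxypyrimidin-5-yl changes that amount.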